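Three analogues at the assay limit, fourth pending

This account rests on a few compounds, and the source may have more. Where it says the series, first, only, none or still open, it means among the compounds named here.

Compound 1 `Cc1ccc(Nc2ncc(Cl)c(Nc3ccccc3C)n2)cc1` and compound 2 `Cc1ccccc1Nc1nc(NCc2ccco2)ncc1Cl` share a core and differ by 4-methylphenyl in place of (furan-2-yl)methyl on a nitrogen on an aromatic ring. In a functional assay on Jurkat cells (Homo sapiens) for inhibition, read by CCK-8 assay, with a stated time of 48 h (a higher number here means a weaker inhibitor of growth, a lower number a stronger inhibitor of growth), compound 1 gives only a limit, > 100000 nM. Compound 2 also gives only a limit in this assay, > 100000 nM. The step that the two limits leave unreadable from compound 2 to compound 1 is unreadable because of the limit of > 100000 nM in this assay, at which 3 of the 3 values shown sit.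

Compound 3 `CN1CCN(c2ccc(Nc3ncc(Cl)c(NCc4ccco4)n3)nc2)CC1` has a different core; the difference between the two cores is not broken down here. In this assay compound 3 gives only a limit, > 100000 nM.

Compound 4 `Cc1ccc(Nc2nc(Nc3ccc(N4CCN(C)CC4)cn3)ncc2Cl)cc1` differs from compound 3 by 4-methylphenyl in place of (furan-2-yl)methyl on a nitrogen on an aromatic ring, the same change as from compound 2 to compound 1, at the same place. That change gave no readable movement once, and compound 3 itself sits at the limit of > 100000 nM in this assay, at which 3 of the 3 values shown sit, so compound 4 is expected to stay at the limit. The expected step is a number no higher from compound 3 to compound 4 (the limit leaves the size open). For compound 4 the estimate is 100000 nM, within 30000 nM to 300000 nM.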

Compound 4, concentration for 50% growth inhibition: 30900 nM
Estimate against measurement, compound 4: 3.2-fold (0.51 log units) above; the measured number falls inside the stated range.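

In this assay, 4-methylphenyl in place of (furan-2-yl)methyl on the nitrogen gives an at least 3.2-fold lower number from compound 3 to compound 4 (0.51 log units; beyond the scatter), so on this core the change lowers the number. On these data alone, the full size of the step stays open because compound 3 gives only a limit: the limit of > 100000 nM in this assay, at which 3 of the 4 values shown sit. The same change from compound 2 to compound 1 cannot be read, as both compounds give only limits, so the series shows one readable step on one core and does not show that the change carries from one core to another.

Still open, as far as these compounds go, is whether a carboxylic acid, an amine or a longer chain in place of 4-methylphenyl on that nitrogen would lower the number further. Also open, from the compounds shown here alone, is whether any such group would give a readable step on both cores.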